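The compounds below may be only part of what the source reports. "The series", "measured", "known", "first", "only" and "open" are said of these compounds alone.

Of the compounds shown here, three share one core and have been tested in a functional assay on SGC-7901 cells (Homo sapiens) for antiproliferative activity, read by MTT assay, with a stated time of 24 h; a lower number here means a stronger inhibitor, a higher number a weaker inhibitor. Compound 1 `O=c1[nH]cc(S(=O)(=O)Nc2ccccc2-c2cn(-c3ccccc3)nn2)c(=O)[nH]1` gives 11800 nM. Within the data shown here, compound 2 `Cc1ccccc1-n1cc(-c2ccccc2NS(=O)(=O)c2c[nH]c(=O)[nH]c2=O)nn1` gives 9570 nM, and the only single-point step measured, a 1.2-fold lower number from compound 1 to compound 2 (0.09 log units; within the scatter), adds a methyl group without a clear effect. Compound 3 `O=c1[nH]cc(S(=O)(=O)Nc2cccc(-c3cn(-c4ccccc4)nn3)c2)c(=O)[nH]1` gives 17200 nM, a number that differs from those of compound 1 and compound 2 only within the usual scatter, so the three cannot be told apart. Compound 4 `O=c1[nH]cc(S(=O)(=O)Nc2cccc(-c3cn(-c4ccccc4F)nn3)c2)c(=O)[nH]1` differs from compound 3 by fluoro in place of hydrogen on an aromatic carbon. Among the measured compounds shown here, no measured step addresses a fluoro group; the one step on record, a small addition to an aromatic carbon, stayed within the scatter. The step from compound 3 to compound 4 is therefore expected to be a 1.1-fold lower number from compound 3 to compound 4 (0.03 log units; within the scatter). For compound 4 the expected value is 16000 nM, estimated to lie between 7000 nM and 38000 nM.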

Compound 4, half-maximal inhibitory concentration: 16000 nM
Beside the measured number, compound 4's estimate shows no gap at the digits printed; the range from low to high includes it.
By their numbers in this assay, from the lowest: compounds 2, 1, 4 and 3 (each within the scatter of the next).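

In this assay, putting fluoro in place of hydrogen on an aromatic carbon, ortho to a large group, gives a 1.1-fold lower number from compound 3 to compound 4 (0.03 log units; within the scatter), so the change from phenyl to 2-fluorophenyl cannot be told apart from no change at all. This is the only step shown on the framework of compound 3 and the only one with a fluoro group. Nothing available explains this result.

On these data alone, whether an amine, a carboxylic acid or a longer chain at this place would shift the number beyond the scatter remains open. So does whether fluoro would behave the same way on compound 1.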